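Replacing methylsulfanyl with hydroxy: what to expect

The source may hold more compounds than are shown below. What is called first, only, known or untested is meant among the compounds shown, and "the series" means these compounds.

In a functional assay on HEp-2 cells (Homo sapiens) for cytotoxicity (on this read-out lower numbers stand for stronger inhibition and higher numbers for weaker inhibition), compound 1 (`Nc1nc(F)nc2c1nnn2C1O[C@H](CO)[C@@H](O)[C@H]1O`) gives 2000 nM. Compound 2 (`CCOc1nc(N)c2nnn(C3O[C@H](CO)[C@@H](O)[C@H]3O)c2n1`) gives > 75000 nM, which is a limit and not a number. Compound 3 (`CSc1nc(N)c2nn(C3O[C@H](CO)[C@@H](O)[C@H]3O)nc2n1`) gives 25000 nM, the higher of the two actual numbers, well on the weak side of compound 1. Compound 4 (`Nc1nc(O)nc2nn(C3O[C@H](CO)[C@@H](O)[C@H]3O)nc12`) has hydroxy in place of methylsulfanyl on an aromatic carbon. Among the measured compounds shown here, the one measured step that bears on this also replaces a group on an aromatic carbon, with ethoxy in place of fluoro: an at least 37-fold higher number from compound 1 to compound 2 (1.57 log units; beyond the scatter). That step is large, but it is a different swap and starts from a much lower number. A modest rise is therefore expected, a 2.4-fold higher number from compound 3 to compound 4 (0.38 log units; beyond the scatter). Compound 4 is estimated at 60000 nM, within a range from 15000 nM to 200000 nM.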

Compound 4, half-maximal inhibitory concentration: > 75000 nM
Compound 4 gave a limit, no number; the forecaster's own chance of this, stated with the estimate: 45%; middle value at least 1.2-fold (0.09 log units) from the limit.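

In this assay, hydroxy in place of methylsulfanyl on this aromatic carbon, between two ring nitrogen atoms, gives an at least 3.0-fold higher number from compound 3 to compound 4 (0.47 log units; beyond the scatter) and so weaker inhibition. This shows that the methylsulfanyl of compound 3, itself weak, still counts for something at this position. The value of compound 4 is a limit and not a number, so the step gives only a minimum size: the limit of > 75000 nM in this assay, at which 2 of the 4 values shown sit.

Going by these compounds, how far compound 4 lies past that limit stays open. So does whether an amine or a longer chain such as ethylsulfanyl on this carbon would give a number nearer that of compound 3.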